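The source may hold more compounds than are shown below. What is called first, only, known or untested is meant among the compounds shown, and "the series" means these compounds.

Compound 1 `COC(=O)C#CC(O/C=C/C(=O)OC)C1CC1` is the anchor of this small set. In a functional assay on HBL-100 cells (Homo sapiens) for antiproliferative activity, read by sulforhodamine B assay, with a stated time of 48 h (on this read-out lower numbers stand for stronger inhibition of growth and higher numbers for weaker inhibition of growth), compound 1 gives 250 nM, the lowest of the two numbers recorded; its nearest neighbour, compound 3 `Cc1ccc(S(=O)(=O)C#CC(O/C=C/S(=O)(=O)c2ccc(C)cc2)C(C)C)cc1`, gives 3800 nM in this assay, a gap beyond the usual scatter. Compound 2 `C#CCO/C=C/C(=O)OC` is reported in this assay only as a limit, > 100000 nM, and so yields no number for comparison (the limit of > 100000 nM in this assay, at which 1 of the 3 values shown sits).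

The step under consideration leads from compound 1 to the unmeasured compound 4 `CCCCC(C#CC(=O)OC)O/C=C/C(=O)OC`. The two differ in one place (butyl in place of cyclopropyl on a saturated chain carbon bound to an oxygen on an unsaturated carbon and a triple-bonded carbon). The rest of the core of compound 1, including the propiolate ester and the enol ether chain, is kept.

Among the compounds with values here, no step between two measured compounds mirrors this exchange, so its size cannot be read from the data. The swap of one small saturated group for another of similar size gives no ground to expect a step beyond the scatter in this assay, in either direction. Compound 4 is therefore expected to give about 300 nM (estimated range 100 nM to 900 nM), an expected step of a 1.2-fold higher number from compound 1 to compound 4 (0.08 log units; within the scatter).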

Compound 4, concentration for 50% growth inhibition: 250 nM
Compound 4: the middle estimate sits 1.2-fold (0.08 log units) above what was measured; the range from low to high includes it.
By their numbers in this assay, from the lowest: compounds 1 and 4 (each within the scatter of the next); then compound 3. At a limit, above all of these: compound 2.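

In this assay the exchange of cyclopropyl for butyl shows no change at the digits printed from compound 1 to compound 4 (within the scatter). Within the data shown here, at this carbon, then, the three-membered ring is not needed to keep the number of compound 1, and an open butyl chain serves equally well, something the earlier compounds, no two of which differed in one place, could not show. Nothing measured here bears on why this exchange leaves the number in place.

Going by these compounds, whether the same position also tolerates a longer chain, a phenyl ring or a chain carrying an amine or a carboxylic acid remains open. The compounds shown also hold no single exchange at the propiolate ester or the enol ether chain, so what each of these parts contributes to growth inhibition cannot yet be told.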